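A few compounds are considered here, and "the series" means these few. Any claim that something is new, unique, unknown or untested is made for them only; others in the source may bear on it.

In a functional assay on CHO cells for positive allosteric modulation of metabotropic glutamate receptor 2 (Homo sapiens), read by GTPgammaS binding, with a stated time of 30 min (on this read-out higher numbers stand for larger maximal responses and lower numbers for smaller maximal responses), compound 1 `CCc1cnc2c(C#N)c(N3CCC(c4ccccc4)CC3)ccn12` gives 225%, compound 2 `CCc1nnc2c(C#N)c(N3CCC(c4ccccc4)CC3)ccn12` gives 247%, and compound 3 `CCCc1cnc2c(C#N)c(N3CCC(c4ccccc4)CC3)ccn12` gives 254%. Compound 2 thus stands second highest of the three: its gap to compound 3 lies within the scatter, while compound 1 sits lower than compound 2 by a margin beyond it. Among the compounds with values here, only one measured step changes a single place, a number 29 percentage points higher from compound 1 to compound 3 (beyond the scatter), a methyl in place of hydrogen on a saturated chain carbon two bonds along the chain from an aromatic carbon. Compound 4 `N#Cc1c(N2CCC(c3ccccc3)CC2)ccn2c(CC3CC3)nnc12` differs from compound 2 by cyclopropyl in place of methyl on a saturated chain carbon bound to an aromatic carbon, a growth of the same chain. That single modest step is all that bears on it. Compound 4 is therefore expected to show a number 11 percentage points higher from compound 2 to compound 4 (beyond the scatter), a small rise or none beyond the scatter, with an estimated value of 258% and a range from 225% to 292%.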

Compound 4, largest response reached (Emax), in percent of the reference or control that the assay uses: 278%
For compound 4 the middle estimate is 20 percentage points below the measured one; the range from low to high includes it.
By their numbers in this assay, from the lowest: compound 1; then compounds 2 and 3 (each within the scatter of the next); then compound 4.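

The change gives a number 31 percentage points higher from compound 2 to compound 4 (beyond the scatter) in this assay and shows that the saturated chain carbon bound to an aromatic carbon can carry cyclopropyl in place of methyl with a clear gain in maximal response. The earlier compounds shown here showed only a methyl added to an open chain, on the core of compound 1, so a three-membered ring at this place is new. No measurement shown here accounts for the rise.

From the compounds shown here alone, whether the gain needs the ring or only the added carbons stays open, and an open butyl chain or a cyclobutyl on the core of compound 2 would separate the two. Going by these compounds, whether cyclopropylmethyl gives the same gain on the core of compound 1 also stays open.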